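Working notes on the amide tail change to compound 4

The compounds below may be only part of what the source reports. "The series", "measured", "known", "first", "only" and "open" are said of these compounds alone.

Among the measured compounds shown here, the three measured members differ only in the group on the amide-type nitrogen and were all run in an ADME assay on TZM cells (Homo sapiens) for cytotoxicity, with a stated time of 1 days; a lower number here means that less compound is tolerated, a higher number that more compound is tolerated. Compound 1 `Cc1cc(C#N)cc(C)c1Oc1nc(Nc2ccc(C#N)cc2)ncc1/C=C/C(=O)NC1CC1` gives > 221 nM, which is a limit of the assay rather than a number. Compound 2 `Cc1cc(C#N)cc(C)c1Oc1nc(Nc2ccc(C#N)cc2)ncc1/C=C/C(=O)NC1CCN(S(C)(=O)=O)CC1` gives > 175 nM, again only a limit. Compound 3 `Cc1cc(C#N)cc(C)c1Oc1nc(Nc2ccc(C#N)cc2)ncc1/C=C/C(=O)NC1CCN(S(C)(=O)=O)C1` gives > 179 nM, also a limit. Compound 3 therefore stands on a limit, and the two further values shown are limits as well, so the steps a step that the two limits leave unreadable from compound 1 to compound 2, a step that the two limits leave unreadable from compound 1 to compound 3 and a step that the two limits leave unreadable from compound 2 to compound 3 cannot be sized; what the measurements offer is the limit of > 175 nM in this assay, at which 1 of the 3 values shown sits, the limit of > 179 nM in this assay, at which 1 of the 3 values shown sits, and (the limit of > 221 nM in this assay, at which 1 of the 3 values shown sits). Compound 4 `Cc1cc(C#N)cc(C)c1Oc1nc(Nc2ccc(C#N)cc2)ncc1/C=C/C(=O)N1CCN(C=O)CC1` carries the change (4-formylpiperazin-1-yl in place of (1-(methylsulfonyl)pyrrolidin-3-yl)amino on a carbonyl carbon), on a carbonyl carbon whose other neighbour is a double-bonded chain carbon. For the measured compounds named here, since none of the measured steps has a readable size, no step beyond the scatter is expected in this assay for this change. The expected step is a step that the limit leaves unreadable from compound 3 to compound 4. Compound 4 is estimated at 200 nM, between 150 nM and 600 nM, most likely reported again only as a limit.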

Compound 4, half-maximal cytotoxic concentration: > 197 nM
Compound 4: no number, only a limit; the forecaster's own chance of this, stated with the estimate: 80%; the middle value does not contradict the limit.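

In this assay, among the compounds shown here, compound 4 gives > 197 nM as a limit, and since compound 1, compound 2 and compound 3 also stand on limits, no step to compound 4 can be read. The compounds shown leave open where any actual cytotoxic concentration lies and whether changing the amide tail shifts it.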